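The source may hold more compounds than are shown below. What is called first, only, known or untested is meant among the compounds shown, and "the series" means these compounds.

Compound 1 `CCN(CC)S(=O)(=O)NC(=O)Nc1c(C(C)C)cccc1C(C)C` carries a diethylamino group on a sulfonyl sulfur. In an assay on liver for inhibition of sterol O-acyltransferase 1 (Rattus norvegicus), using microsomes (on this read-out lower numbers stand for stronger inhibition and higher numbers for weaker inhibition), compound 1 gives 2500 nM. Among the three compounds measured, compound 3 `CCCCN(C)S(=O)(=O)NC(=O)Nc1c(C(C)C)cccc1C(C)C`, which carries butyl(methyl)amino in place of diethylamino on that sulfur, lies nearest to it: in this assay compound 3 gives 2300 nM. Compound 2 `CC(C)c1cccc(C(C)C)c1NC(=O)NS(=O)(=O)N1CCCC1`, with pyrrolidin-1-yl in place of diethylamino, lies furthest away: in this assay compound 2 gives 15000 nM, and a 6.0-fold higher number from compound 1 to compound 2 (0.78 log units; beyond the scatter); likewise a 6.5-fold lower number from compound 2 to compound 3 (0.81 log units; beyond the scatter).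

Compound 4 `CCCCN(CC)S(=O)(=O)NC(=O)Nc1c(C(C)C)cccc1C(C)C` has not yet been measured. It differs from compound 1 in one place: ethyl in place of hydrogen on a saturated chain carbon, two bonds along the chain from a sulfonamide nitrogen. For the measured compounds named here, the step that bears most directly on this change is the one from compound 1 to compound 3, because a 1.1-fold lower number from compound 1 to compound 3 (0.04 log units; within the scatter), and that step also alters only the groups on the sulfonamide nitrogen. The larger step from compound 1 to compound 2 concerns pyrrolidin-1-yl and is not taken to apply here. Compound 4 is therefore expected to stay close to compound 1, with a 1.1-fold lower number from compound 1 to compound 4 (0.06 log units; within the scatter) remaining within the scatter. The estimate for compound 4 in this assay is 2200 nM, with an expected range from 1000 nM to 5000 nM.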

Compound 4, half-maximal inhibitory concentration: 1200 nM
The estimate for compound 4 lay 1.8-fold (0.26 log units) above the measured number; measured number inside the range.
By their numbers in this assay, from the lowest: compounds 4, 3 and 1 (each within the scatter of the next, the first and the last beyond it); then compound 2.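

Within this assay, ethyl in place of hydrogen on a saturated chain carbon, two bonds along the chain from a sulfonamide nitrogen, gives a 2.1-fold lower number from compound 1 to compound 4 (0.32 log units; beyond the scatter) and so turns diethylamino into butyl(ethyl)amino with a step beyond the scatter, which the earlier change from diethylamino to butyl(methyl)amino did not produce. The other single change leading to compound 4, methyl in place of hydrogen on a saturated chain carbon bound to a sulfonamide nitrogen, gives a 1.9-fold lower number from compound 3 to compound 4 (0.28 log units; within the scatter) and stays within the scatter, so among compounds 1, 3 and 4 only the two ends of the series are separated. Butyl(ethyl)amino in place of pyrrolidin-1-yl gives a 13-fold lower number from compound 2 to compound 4 (1.10 log units; beyond the scatter) as a large step, which widens the separation of compound 2 from the other compounds, all of which carry two separate chains on that nitrogen.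

The compounds shown leave open whether dibutylamino, a hexyl chain on that nitrogen, or a larger ring such as piperidin-1-yl or morpholin-4-yl would continue or reverse this trend. Nothing available here accounts for the size of these steps.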